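Replacing Nitro with Ethoxycarbonyl on the Shared Core

The source may hold more compounds than are shown below. What is called first, only, known or untested is meant among the compounds shown, and "the series" means these compounds.

Compound 1 `COc1ccc2oc(=O)c(=O)[nH]c2c1`: 15000 nM
Compound 2 `O=c1[nH]c2cc([N+](=O)[O-])ccc2oc1=O`: 800 nM

In a functional assay with Rattus norvegicus as the target (on this read-out lower numbers stand for stronger inhibition and higher numbers for weaker inhibition), compound 2 holds the lower of the two numbers, with compound 1 well above it. The unmeasured compound 3 `CCOC(=O)c1ccc2oc(=O)c(=O)[nH]c2c1` has ethoxycarbonyl in place of nitro on an aromatic carbon.

For the measured compounds named here, one measured step bears on this change: a 19-fold lower number from compound 1 to compound 2 (1.27 log units; beyond the scatter), a large step that came with nitro in place of methoxy. Going by the values given here, no measured compound carries ethoxycarbonyl, so this evidence is indirect. Since compound 3 gives up the nitro seen in that step, a moderate move to a higher number is expected in this assay, probably beyond the scatter but smaller than the measured step. The expected change is a 3.8-fold higher number from compound 2 to compound 3 (0.57 log units; beyond the scatter). Compound 3 is estimated at 3000 nM, with an expected range of 800 nM to 12000 nM.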

Compound 3, half-maximal inhibitory concentration: 10000 nM
Beside the measured number, compound 3's estimate is 3.3-fold (0.52 log units) below it; measured number inside the range.
By their numbers in this assay, from the lowest: compound 2; then compounds 3 and 1 (each within the scatter of the next).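

In this assay, ethoxycarbonyl does not hold on this aromatic carbon what nitro held: the exchange brings a 13-fold higher number from compound 2 to compound 3 (1.10 log units; beyond the scatter) and so undoes nearly all of the advantage of compound 2. Set against methoxy, ethoxycarbonyl gives a 1.5-fold lower number from compound 1 to compound 3 (0.18 log units; within the scatter) and no difference can be read, so among these three compounds only the nitro compound stands apart, even though nitro and ethoxycarbonyl count alike in double bonds outside aromatic rings and in hydrogen-bond acceptors. Nothing measured here offers an explanation for the gap between the two groups.

Going by these compounds, whether any other group on this carbon, such as a carboxylic acid, a nitrile or an amine, would come close to nitro remains open. So does whether the nitro step would hold at another carbon of the ring.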